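This account rests on a few compounds, and the source may have more. Where it says the series, first, only, none or still open, it means among the compounds named here.

Working notes on the series. Among the compounds with values here, compound 1 `C/C(=C\c1cc(-c2ccc(F)nc2)co1)C(N)=O` and compound 2 `C/C(=C\c1cccc(-c2ccccc2)c1)C(N)=O` are the two measured members. In a functional assay on MCF7 cells (Homo sapiens) for cytotoxicity, read by CCK-8 assay, with a stated time of 24 h (on this read-out higher numbers stand for weaker inhibition and lower numbers for stronger inhibition), compound 1 gives 14100 nM, and in this assay compound 2 gives 6540 nM, the lower of the two numbers; the gap between them lies beyond the usual scatter. Compound 3 `C/C(=C\c1cccc(-c2ccc(C)cc2)c1)C(N)=O` is not yet measured; it differs from compound 2 by methyl in place of hydrogen on an aromatic carbon. Within the data shown here, no step between measured compounds informs this change, so in this assay no movement beyond the scatter is expected, in either direction. For compound 3 the estimated value in this assay is 5500 nM, with a range from 2000 nM to 15000 nM, an expected step of a 1.2-fold lower number from compound 2 to compound 3 (0.08 log units; within the scatter).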

Compound 3, half-maximal inhibitory concentration: 6710 nM
For compound 3 the middle estimate is 1.2-fold (0.09 log units) below the measured one, within the range that was stated.
By their numbers in this assay, from the lowest: compounds 2 and 3 (each within the scatter of the next); then compound 1.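

In this assay, methyl in place of hydrogen on an aromatic carbon, para to a large group, gives a 1.0-fold higher number from compound 2 to compound 3 (0.01 log units; within the scatter). Within the data shown here, this is the first step that can be read at this position, and this single added carbon brings no movement beyond the scatter. No measurement here bears on the reason for this. From the compounds shown here alone, whether an amine, a carboxylic acid or a longer chain at the same position would also stay within the scatter remains open. Also open, going by these compounds, is whether methyl on the core of compound 1 would give a step of similar size.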